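The compounds below may be only part of what the source reports. "The series", "measured", "known", "first", "only" and "open" are said of these compounds alone.

Measured in a functional assay on KYSE-70 cells for antiproliferative activity against KYSE-70 cell line (Homo sapiens), read by MTT assay, with a stated time of 72 h; a higher number here means a weaker inhibitor, a lower number a stronger inhibitor:
compound 1 `COc1ccc(-c2ccc3c(C(=O)Nc4cccc(F)c4)cc(=O)[nH]c3c2)cc1`: > 20000 nM
compound 2 `O=C(Nc1cccc(F)c1)c1cc(=O)[nH]c2cc(C3CC3)ccc12`: > 20000 nM
compound 3 `O=C(Nc1cccc(F)c1)c1cc(=O)[nH]c2cc(-c3ccncc3)ccc12`: > 20000 nM

Compound 3 stands at > 20000 nM, which is a limit and not a number. The same holds across the series, which sits entirely at the limit of > 20000 nM in this assay, at which 3 of the 3 values shown sit.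

Compound 4 `O=C(Nc1cccc(F)c1)c1cc(=O)[nH]c2cc(-c3ccc(F)nc3)ccc12` carries 6-fluoropyridin-3-yl in place of the pyridin-4-yl of compound 3, on an aromatic carbon: 6-fluoropyridin-3-yl in place of pyridin-4-yl on an aromatic carbon.

The measured changes at this carbon are a step that the two limits leave unreadable from compound 1 to compound 2, a step that the two limits leave unreadable from compound 1 to compound 3 and a step that the two limits leave unreadable from compound 2 to compound 3. None of them gives a size, yet a phenyl-type, a cycloalkyl and a pyridyl group all ended at the same limit. In this assay no clear step in either direction is therefore expected, and a further limit is the likeliest report. The expected change is a step that the limit leaves unreadable from compound 3 to compound 4, an estimate with little behind it. For compound 4 the estimated value is 22000 nM. The expected range for compound 4 runs from 9000 nM to 50000 nM.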

Compound 4, half-maximal inhibitory concentration: > 20000 nM
Compound 4: no number, only a limit; the forecaster's own chance of this, stated with the estimate: 75%; the middle value does not contradict the limit.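

In this assay compound 4 gives > 20000 nM as a limit and not a number. Going by these compounds alone, no step between compound 4 and compound 1, compound 2 or compound 3 can be read. The compounds shown leave open whether any group at this aromatic carbon gives a measurable value.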